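Cytotoxicity notes: tetrazole in place of nitrile on the shared core

The compounds below may be only part of what the source reports. "The series", "measured", "known", "first", "only" and "open" are said of these compounds alone.

Compound 3 `N#Cc1ccc(-c2ccc(O)c(=O)[nH]2)cc1` has been run in an ADME assay on MDCK cells (Canis lupus familiaris) for cytotoxicity, read by MTT assay, with a stated time of 4 days; on this read-out lower numbers stand for stronger inhibition and higher numbers for weaker inhibition. In this assay compound 3 gives > 100000 nM, which is a limit of the assay and not a number. Compound 1 `O=c1[nH]cc(-c2ccc(F)cc2)cc1O` gives > 100000 nM in this assay, likewise a limit. Compound 2 `O=c1[nH]c(-c2ccc(F)cc2)ccc1O` gives > 100000 nM, also a limit. All three values sit at the limit of > 100000 nM in this assay, at which 3 of the 3 values shown sit, so compound 3 cannot be set apart from compound 1 or compound 2 on the numbers shown.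

Compound 4 `O=c1[nH]c(-c2ccc(-c3nnn[nH]3)cc2)ccc1O` differs from compound 3 by 1H-tetrazol-5-yl in place of cyano on an aromatic carbon. Going by the values given here, the only measured step touching this position is a step that the two limits leave unreadable from compound 2 to compound 3; it is unreadable because both of its ends rest at the limit of > 100000 nM in this assay, at which 3 of the 3 values shown sit. Among the compounds with values here, no measured step therefore supports a change beyond the scatter in this assay in either direction for compound 4. Compound 4 is expected to return a limit again in this assay, estimated at 150000 nM with a range from 100000 nM to 300000 nM. The expected step is a step that the limit leaves unreadable from compound 3 to compound 4, nothing readable beyond the scatter.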

Compound 4, half-maximal inhibitory concentration: > 100000 nM
Compound 4 gave a limit, no number (the forecaster's own chance of this, stated with the estimate: 85%); the middle value does not contradict the limit.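

The steps from compound 2 and compound 3 to compound 4 in this assay cannot be read, because both ends of each rest on a limit: the limit of > 100000 nM in this assay, at which 4 of the 4 values shown sit.

The compounds shown leave open whether fluoro, cyano and 1H-tetrazol-5-yl differ at all on this read-out.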